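The source may report more compounds than this note shows. Statements on the series, on what has been measured and on what is new or still open speak of the compounds shown alone.

In a functional assay (aorta) with Oryctolagus cuniculus as the target (on this read-out higher numbers stand for weaker binding and lower numbers for tighter binding), compound 3 `Fc1ccc(C(c2ccc(F)cc2)C2CCN(CCCOc3ccccc3)CC2)cc1` stands lowest of the three measured compounds at 1.59 nM on this read-out. Compound 1 `NC(=O)c1ccc(OCCCN2CCC(C(c3ccc(F)cc3)c3ccc(F)cc3)CC2)cc1` gives 31.6 nM and compound 2 `Nc1ccc(OCCCN2CCC(C(c3ccc(F)cc3)c3ccc(F)cc3)CC2)cc1` gives 31.6 nM in the same test.

The next structure is compound 4 `CN(CCCN1CCC(C(c2ccc(F)cc2)c2ccc(F)cc2)CC1)c1ccccc1`, with methyl(phenyl)amino in place of phenoxy on a saturated chain carbon, three bonds along the chain from an amine nitrogen in a ring.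

Going by the values given here, no measured step replaces phenoxy as a whole. All three change a substituent on an aromatic carbon, so they bear only indirectly. Two were large (a 20-fold lower number from compound 1 to compound 3 (1.30 log units; beyond the scatter); a 20-fold lower number from compound 2 to compound 3 (1.30 log units; beyond the scatter)), while the third stayed within the scatter (no change at the digits printed from compound 1 to compound 2 (within the scatter)). These steps show that the read-out can move strongly with a single change, and both other compounds read higher than compound 3.

A moderate upward step is therefore expected in this assay and is estimated as a 2.5-fold higher number from compound 3 to compound 4 (0.40 log units; beyond the scatter) with wide uncertainty. The expected value for compound 4 is 4 nM (estimated range 1.2 nM to 16 nM).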

Compound 4, dissociation constant: 2 nM
Estimate against measurement, compound 4: 2.0-fold (0.30 log units) above, and the stated range covers the measured number.
By their numbers in this assay, from the lowest: compounds 3 and 4 (each within the scatter of the next); then compounds 1 and 2 (each within the scatter of the next).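

In this assay, replacing phenoxy as a whole on the saturated chain carbon leaves the number within the scatter (a 1.3-fold higher number from compound 3 to compound 4 (0.10 log units; within the scatter)), so a low number on this read-out does not depend on phenoxy itself. Methyl(phenyl)amino also stands well apart from both substituted phenoxy groups, with 4-aminophenoxy (a 16-fold lower number from compound 2 to compound 4 (1.20 log units; beyond the scatter)) and with 4-carbamoylphenoxy (a 16-fold lower number from compound 1 to compound 4 (1.20 log units; beyond the scatter)). Among the steps at this position, the two involving a substituted phenoxy group are therefore large, while the one from unsubstituted phenoxy is not.

No available data give a reason for these steps. Open points are whether phenylamino, phenylthio or a longer chain would read like compound 4, and whether an amino or carbamoyl group on the ring of methyl(phenyl)amino would raise the number as it does on phenoxy.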